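A small swap on a hydrazone side group

A few compounds are considered here, and "the series" means these few. Any claim that something is new, unique, unknown or untested is made for them only; others in the source may bear on it.

In a functional assay on HeLa cells (Homo sapiens) for inhibition, read by MTT assay, with a stated time of 48 h (a higher number here means a weaker inhibitor, a lower number a stronger inhibitor), compound 2 (`CCOC(=O)C1=C(NN=C(C#N)C#N)Nc2[nH]nc(C)c2C1c1ccc(N(C)C)cc1`) gives 15200 nM and stands level with compound 3 (`CCOC(=O)C1=C(N/C=N/c2ncc(-c3ccccc3)s2)Nc2[nH]nc(C)c2C1c1ccc(N(C)C)cc1`) at 15400 nM within the usual scatter. Compound 1 (`CCOC(=O)C1=C(N/N=C(\c2ccc([N+](=O)[O-])cc2)N2CCN(c3ccc(F)cc3)CC2)Nc2[nH]nc(C)c2C1c1ccc(N(C)C)cc1`) gives 87000 nM and is clearly the weaker inhibitor of the three. Compound 4 (`CCOC(=O)C1=C(N/N=C(/Cl)C#N)Nc2[nH]nc(C)c2C1c1ccc(N(C)C)cc1`) keeps the shared core of compound 2 and differs by one swap: a group of 5 heavy atoms (2 carbon, 2 nitrogen, 1 chlorine; no ring) in place of a group of 6 heavy atoms (3 carbon, 3 nitrogen; no ring), on an amine nitrogen here. Among the compounds with values here, no measured pair shows this change alone, so the expectation starts from compound 2 at 15200 nM as its anchor. The expected change in this assay is small, with a 1.0-fold lower number from compound 2 to compound 4 (0.01 log units; within the scatter) estimated to stay within the scatter and no direction favoured. Compound 4 is expected at 15000 nM (estimated range 6000 nM to 38000 nM).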

Compound 4, half-maximal inhibitory concentration: 26200 nM
Compound 4: the middle estimate sits 1.7-fold (0.24 log units) below what was measured, and the stated range covers the measured number.
By their numbers in this assay, from the lowest: compounds 2, 3 and 4 (each within the scatter of the next); then compound 1.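

In this assay, the swap on the amine nitrogen gives a 1.7-fold higher number from compound 2 to compound 4 (0.24 log units; within the scatter) and so stays within the scatter: the group of 5 heavy atoms, which contains chlorine, reads like the group of 6 heavy atoms it replaces. This is the first step shown in which two compounds differ in only one place, so the shared core can be set aside in reading it. Nothing shown here bears on why the two groups read alike. On these data alone, whether another group on this amine nitrogen, such as a carboxylic acid or a longer carbon chain, would shift the number beyond the scatter remains open.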